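Dimethylaminomethyl in place of diethylaminomethyl on the ring nitrogen

The source may report more compounds than this note shows. Statements on the series, on what has been measured and on what is new or still open speak of the compounds shown alone.

Measured so far in a functional assay on MCF7 cells (Homo sapiens) for cytotoxicity, read by sulforhodamine B assay, with a stated time of 48 h; a higher number here means a weaker inhibitor of growth, a lower number a stronger inhibitor of growth:
compound 1, `Cc1ccc2nc(/N=C3\C(=O)N(CN(C)C)c4cccc(Br)c43)sc2c1`, 18000 nM
compound 2, `Cc1ccc2nc(/N=C3\C(=O)N(CN(C)C)c4ccccc43)sc2c1`, 29200 nM
compound 3, `CCN(CC)CN1C(=O)/C(=N\c2nc3ccc(C)cc3s2)c2c(Cl)cccc21`, 19200 nM

Compound 3 stands second highest of the three numbers in this assay ; its nearest neighbour is compound 1 and its furthest is compound 2, and both gaps are within the scatter, so the three measured compounds cannot be ordered against one another on these data.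

Compound 4, `Cc1ccc2nc(/N=C3\C(=O)N(CN(C)C)c4cccc(Cl)c43)sc2c1`, differs from compound 3 only in the group on the saturated chain carbon bound to the amide-type nitrogen in the ring: dimethylamino in place of diethylamino on a saturated chain carbon bound to an amide-type nitrogen in a ring.

Within the data shown here, the single measured step, a 1.6-fold higher number from compound 1 to compound 2 (0.21 log units; within the scatter), concerns hydrogen in place of bromo on an aromatic carbon and leaves the chain on the ring nitrogen untouched, so no measured step bears on the change from compound 3 to compound 4. With nothing in the series speaking to this position, and all three measured values within the scatter of one another, no step beyond the scatter is expected in this assay . Compound 4 is therefore estimated at 19000 nM, with a range of 9000 nM to 40000 nM, which means an expected step of a 1.0-fold lower number from compound 3 to compound 4 (0.00 log units; within the scatter).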

Compound 4, concentration for 50% growth inhibition: 20700 nM
For compound 4 the middle estimate is 1.1-fold (0.04 log units) below the measured one; low and high end bracket the measured number.
By their numbers in this assay, from the lowest: compounds 1, 3, 4 and 2 (each within the scatter of the next).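

In this assay, the pair that isolates the amine on the chain gives a 1.1-fold higher number from compound 3 to compound 4 (0.03 log units; within the scatter), so dimethylamino in place of diethylamino on a saturated chain carbon bound to an amide-type nitrogen in a ring produces no step beyond the scatter. With dimethylamino held fixed, a 1.4-fold lower number from compound 2 to compound 4 (0.15 log units; within the scatter) and a 1.2-fold higher number from compound 1 to compound 4 (0.06 log units; within the scatter) bring chloro into the earlier comparison of hydrogen and bromo on the aromatic carbon, and all three steps among these groups lie within the scatter. No measurement at hand accounts for any of these steps.

Going by these compounds, whether a cyclic amine such as morpholine or piperidine on the same chain would also stay within the scatter remains open. Also open, on these data alone, are other groups on the aromatic carbon, such as methoxy or nitro, and whether the amine step holds with bromo or hydrogen there.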